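The source may report more compounds than this note shows. Statements on the series, on what has been measured and on what is new or still open speak of the compounds shown alone.

In an ADME assay on MT4 cells (Homo sapiens) for cytotoxicity (on this read-out higher numbers stand for lower toxicity in this test and lower numbers for higher toxicity in this test), compound 3 (`COC(=O)N[C@H](C(=O)NN(CCC[C@@](O)(Cc1ccccc1)C(=O)N[C@H]1c2ccccc2C[C@H]1O)Cc1ccc(-c2cccnc2)cc1)C(C)(C)C`) gives > 10000 nM as a limit and not a number. Compound 1 (`COC(=O)N[C@H](C(=O)NN(CCC[C@@](O)(Cc1ccccc1)C(=O)N[C@H]1c2ccccc2C[C@H]1O)CC(C)C)C(C)(C)C`) gives > 10000 nM as a limit as well. Compound 2 (`COC(=O)N[C@H](C(=O)NN(CCC[C@@](O)(Cc1ccccc1)C(=O)N[C@H]1c2ccccc2C[C@H]1O)Cc1ccc(I)cc1)C(C)(C)C`) likewise gives > 10000 nM as a limit. The whole measured set therefore shares one ceiling (the limit of > 10000 nM in this assay, at which 3 of the 3 values shown sit) and compound 3 has no exact position within it.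

Compound 4 (`COC(=O)N[C@H](C(=O)NN(CCC[C@@](O)(Cc1ccccc1)C(=O)N[C@H]1c2ccccc2C[C@H]1O)Cc1ccc(-c2ccsc2)cc1)C(C)(C)C`) carries thiophen-3-yl in place of pyridin-3-yl on an aromatic carbon and otherwise keeps the core of compound 3.

The measured step nearest to this change, pyridin-3-yl in place of iodo at the same aromatic carbon, is a step that the two limits leave unreadable from compound 2 to compound 3 in this series. The two replacements of isopropyl are a step that the two limits leave unreadable from compound 1 to compound 2 and a step that the two limits leave unreadable from compound 1 to compound 3 on the same reading. None of the three has a readable size, so they give no direction for the new swap. Within the data shown here, they show only that three different groups at this end of the molecule all stay at the limit.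

The estimated change is a step that the limit leaves unreadable from compound 3 to compound 4 and no step beyond the scatter is expected in either direction in this assay for this swap. For compound 4 the estimated value is 12000 nM with an expected range from 5000 nM to 30000 nM and a report as a limit is the likeliest outcome.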

Compound 4, half-maximal cytotoxic concentration: > 10000 nM
Compound 4 gave a limit, no number; the forecaster's own chance of this, stated with the estimate: 85%; the middle value does not contradict the limit.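

In this assay compound 4 gives > 10000 nM, a limit and not a number. Its steps from compound 1, compound 2 and compound 3 therefore cannot be read. The compounds shown leave open how their half-maximal cytotoxic concentrations rank, and whether any change to this end of the molecule would give a measurable value.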